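A Methyl Added to the Carboxyphenyl Ring

The source may report more compounds than this note shows. Statements on the series, on what has been measured and on what is new or still open speak of the compounds shown alone.

Compound 2 `Cc1c(OCCCCOc2cccc(C(=O)O)c2)ccc(C(=O)CC2CCCC2)c1O` gives 451 nM in an assay on HEK293 cells for positive allosteric modulation of metabotropic glutamate receptor 2 (Rattus norvegicus), read by thallium flux, with a stated time of 2.5 min; a higher number here means that more compound is needed for the effect, a lower number that less compound is needed; this is the lowest of the two numbers measured, and its nearest neighbour, compound 1 `Cc1c(OCCCCOc2ccc(C(=O)O)cc2)ccc(C(=O)CC2CCCC2)c1O`, gives 824 nM in this assay. Among the measured compounds shown here, the one step between them, a 1.8-fold lower number from compound 1 to compound 2 (0.26 log units; within the scatter), concerns the carboxyphenyl ring attached to an oxygen on a saturated carbon. Compound 3 `Cc1ccc(C(=O)O)cc1OCCCCOc1ccc(C(=O)CC2CCCC2)c(O)c1C` differs from compound 2 by methyl in place of hydrogen on an aromatic carbon, on an aromatic carbon of a six-membered aromatic ring of carbon only, ortho to a large group and para to a carboxy group. For the measured compounds named here, no measured step puts a methyl anywhere, and the only step touching this ring stayed within the scatter, so nothing points to a change beyond the scatter. Compound 3 is therefore expected to give 450 nM, with a range from 150 nM to 1400 nM, in this assay. This estimate means a 1.0-fold lower number from compound 2 to compound 3 (0.00 log units; within the scatter), expected to stay within the scatter.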

Compound 3, half-maximal effective concentration: 1290 nM
Beside the measured number, compound 3's estimate is 2.9-fold (0.46 log units) below it; the measured number falls inside the stated range.
By their numbers in this assay, from the lowest: compounds 2, 1 and 3 (each within the scatter of the next, the first and the last beyond it).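

Methyl on this aromatic carbon, ortho to a large group and para to a carboxy group, produced the first modest step beyond the scatter in this assay (a 2.9-fold higher number from compound 2 to compound 3 (0.46 log units; beyond the scatter)), whereas the earlier change on this ring had stayed within it. A single added carbon at this place on the 3-carboxyphenyl ring is therefore enough to raise the number measurably. The 5-carboxy-2-methylphenyl and 4-carboxyphenyl rings, however, cannot be told apart here (a 1.6-fold higher number from compound 1 to compound 3 (0.19 log units; within the scatter)).

The compounds shown offer no measured basis for explaining the methyl step. From the compounds shown here alone, it remains open whether ethyl, methoxy or chlorine at this carbon would shift the number further, and whether methyl on another carbon of the ring would have the same effect.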